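Chloro in Place of Methoxy on the Pendant Aromatic Ring

This account rests on a few compounds, and the source may have more. Where it says the series, first, only, none or still open, it means among the compounds named here.

Measured compounds:
compound 1, `Cc1c(Cl)cccc1-c1cccc(COc2ccc([C@H](CC(=O)O)c3nccn3C)cc2)c1`, 22000 nM
compound 2, `COc1ccccc1-c1cccc(COc2ccc([C@H](CC(=O)O)c3nccn3C)cc2)c1`, "not determined" (no result reported)

Compound 1 was tested in an assay on CHO cells for agonist activity at Free fatty acid receptor 1 (Homo sapiens), read by luminescence, with a stated time of 20 s, in the presence of a further agent that is not named here (on this read-out higher numbers stand for an effect only at larger amounts of compound and lower numbers for an effect already at smaller amounts), and gave 22000 nM. Compound 2 carries no single number in this assay. Compound 3, `Cn1ccnc1[C@@H](CC(=O)O)c1ccc(OCc2cccc(-c3ccccc3Cl)c2)cc1`, is the next step from compound 2: chloro in place of methoxy on an aromatic carbon. For the measured compounds named here, no measured pair shows this exact change, so its direction and size cannot be read from the numbers in hand; only compound 1, with a chloro on a related ring and 22000 nM, offers a rough anchor. Compound 3 is therefore expected to land near 15000 nM, within 3000 nM to 60000 nM.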

Compound 3, half-maximal effective concentration: 56000 nM
Beside the measured number, compound 3's estimate is 3.7-fold (0.57 log units) below it, within the range that was stated.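

In this assay, 2-chlorophenyl in place of 3-chloro-2-methylphenyl gives a 2.5-fold higher number from compound 1 to compound 3 (0.41 log units; beyond the scatter), so a change on this pendant ring does move the read-out, and compound 3 needs a larger amount of compound for its effect. The swap of methoxy for chloro itself cannot be read, as compound 2 has no number. Nothing at hand explains the shift.

Going by these compounds, whether an amine or a nitrile in place of chloro on this ring would lower the number remains open.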